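Changing the Aryl on the Sulfonyl Sulfur of Compound 2

The source may report more compounds than this note shows. Statements on the series, on what has been measured and on what is new or still open speak of the compounds shown alone.

In a functional assay on HeLa cells (Homo sapiens) for cytotoxicity, read by MTT assay, with a stated time of 48 h (on this read-out lower numbers stand for stronger inhibition and higher numbers for weaker inhibition), compound 1 `CCN(CC)c1ccc2cc(C(=O)c3ccc(N4CCN(S(=O)(=O)c5ccc(C(F)(F)F)cc5)CC4)cc3)oc2c1` gives 9720 nM, while compound 2 `CCN(CC)c1ccc2cc(C(=O)c3ccc(N4CCN(S(=O)(=O)c5ccc(Br)c(F)c5)CC4)cc3)oc2c1` gives 20700 nM, the higher of the two numbers measured. For the measured compounds named here, the single structural step recorded so far, a 2.1-fold higher number from compound 1 to compound 2 (0.33 log units; beyond the scatter), shows that the aryl group on the sulfonyl sulfur can move this read-out modestly. Compound 3 `CCN(CC)c1ccc2cc(C(=O)c3ccc(N4CCN(S(=O)(=O)c5ccc(C)cc5)CC4)cc3)oc2c1` carries the change (4-methylphenyl in place of 4-bromo-3-fluorophenyl on a sulfonyl sulfur). Going by the values given here, no measured step covers this exact swap, and the one step at this position was modest in size. For compound 3 only a modest shift is therefore expected, a 1.5-fold lower number from compound 2 to compound 3 (0.17 log units; within the scatter). The estimate for compound 3 is 14000 nM, with a range from 5000 nM to 40000 nM.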

Compound 3, half-maximal inhibitory concentration: 37800 nM
For compound 3 the middle estimate is 2.7-fold (0.43 log units) below the measured one; measured number inside the range.
By their numbers in this assay, from the lowest: compound 1; then compounds 2 and 3 (each within the scatter of the next).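

In this assay, 4-methylphenyl in place of 4-bromo-3-fluorophenyl gives a 1.8-fold higher number from compound 2 to compound 3 (0.26 log units; within the scatter) and so cannot be told apart from repeat measurement. The clearer contrast lies in methyl in place of trifluoromethyl on an aromatic carbon, which gives a 3.9-fold higher number from compound 1 to compound 3 (0.59 log units; beyond the scatter) and is the largest step yet seen at this position. No supporting data are available to explain this difference. Still open, on these data alone, is whether an amine or a carboxylic acid on this aryl ring, or a longer alkyl chain replacing the ring on the sulfonyl sulfur, would give a lower number than compound 1.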